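A few compounds are considered here, and "the series" means these few. Any claim that something is new, unique, unknown or untested is made for them only; others in the source may bear on it.

Compounds measured so far in a functional assay on SK-N-SH cells (Homo sapiens) for inhibition; a lower number here means a stronger inhibitor of growth, a higher number a weaker inhibitor of growth:
- compound 1, `O=c1c2cc([N+](=O)[O-])cnc2sn1-c1ccc(Br)cc1`: 53500 nM
- compound 2, `Cc1cnc2sn(-c3ccc(Br)cc3)c(=O)c2c1`: 21300 nM
- compound 3, `O=c1c2cccnc2sn1-c1ccccc1`: 11200 nM

Compound 3 gives the lowest of the three numbers. Its nearest neighbour is compound 2, whose number is higher by an amount within the usual scatter, so the two cannot be ordered; compound 1 stands furthest away, with a number beyond the scatter above compound 3. Among the compounds with values here, the only single-place step among the measured compounds is a 2.5-fold lower number from compound 1 to compound 2 (0.40 log units; beyond the scatter), a modest gain when the core of compound 1 carries a methyl rather than a nitro group.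

Compound 4, `Cc1ccc(-n2sc3ncccc3c2=O)cc1`, is not yet measured. It differs from compound 3 thus: methyl in place of hydrogen on an aromatic carbon. Within the data shown here, no measured pair shows this change on the phenyl ring; the step from compound 1 to compound 2 concerns a methyl on the core and replaces a nitro group, so it bears on compound 4 only loosely. Among the measured compounds shown here, with no close precedent, the expected step of a 1.2-fold lower number from compound 3 to compound 4 (0.09 log units; within the scatter) is small and not beyond the scatter. Compound 4 is therefore estimated at 9000 nM, between 3000 nM and 30000 nM.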

Compound 4, concentration for 50% growth inhibition: 6200 nM
Compound 4: middle estimate off by 1.5-fold (0.16 log units), on the high side, and the stated range covers the measured number.
By their numbers in this assay, from the lowest: compounds 4, 3 and 2 (each within the scatter of the next, the first and the last beyond it); then compound 1.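

On the six-membered aromatic ring of carbon only, methyl in place of hydrogen, para to a large group, gives a 1.8-fold lower number from compound 3 to compound 4 (0.26 log units; within the scatter) in this assay, so this position takes the added methyl with no change that can be told from the scatter. The earlier step concerned the core, with methyl set against nitro, and showed nothing about this ring. No measurement at hand offers an explanation for the size of this step.

Going by these compounds, it stays open whether a longer chain such as propyl, an amine or a carboxylic acid on the same aromatic carbon would shift the number beyond the scatter. On these data alone, whether a methyl on another carbon of this ring would act as this one does is also open.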